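A few compounds are considered here, and "the series" means these few. Any claim that something is new, unique, unknown or untested is made for them only; others in the source may bear on it.

Three sulfonamides built on closely related cores have been compared in a functional assay on MCF7 cells (Homo sapiens) for cytotoxicity; a higher number here means a weaker inhibitor of growth, a lower number a stronger inhibitor of growth. Compound 1 `COc1ccc(NS(=O)(=O)c2c(F)c(F)c(F)c(Br)c2F)cc1` gives 270 nM, compound 2 `COc1ccc(NS(=O)(=O)c2c(F)cc(F)c(F)c2F)cc1` gives 4500 nM, and compound 3 `COc1ccc(NS(=O)(=O)c2c(F)c(F)c(Br)c(F)c2F)cc1` gives 36000 nM, the highest of the three numbers. Compound 2 arises from compound 1 by hydrogen in place of bromo on an aromatic carbon, and that step is a 17-fold higher number from compound 1 to compound 2 (1.22 log units; beyond the scatter). The difference between the cores of compound 3 and compound 1 is not broken down here. Compound 4 `COc1ccc(NS(=O)(=O)c2c(F)c(F)cc(F)c2F)cc1`, not yet measured, arises from compound 3 by the same kind of change, (hydrogen in place of bromo on an aromatic carbon), although the place differs: here it is meta to two fluoro groups and para to a large group, whereas in compound 1 it is meta to a fluoro group, meta to a large group and para to a fluoro group. Because a 17-fold higher number from compound 1 to compound 2 (1.22 log units; beyond the scatter) raised the number so sharply, and because compound 3 already stands at 36000 nM, compound 4 is expected to give a 2.8-fold higher number from compound 3 to compound 4 (0.44 log units; beyond the scatter). A smaller rise is expected than before, since compound 2 at 4500 nM shows that a core without bromo can still inhibit growth. The estimate for compound 4 is 100000 nM, with a likely range from 20000 nM to 500000 nM.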

Compound 4, concentration for 50% growth inhibition: > 50000 nM
Compound 4 was reported as a limit; the forecaster's own chance of this, stated with the estimate: 40%; the middle value lies beyond the limit too.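

In this assay compound 4 is reported only as a limit, > 50000 nM. On this core, hydrogen in place of bromo gives an at least 1.3-fold higher number from compound 3 to compound 4 (0.14 log units; that floor lies within the scatter), so the floor alone does not establish a rise here, although it does not rule out a large one. The data therefore show neither that the size of the earlier step carries over to this core nor that it fails to do so: the same change on two cores in this assay, a 17-fold higher number (1.22 log units; beyond the scatter) from compound 1 to compound 2 and an at least 1.3-fold higher number (0.14 log units; that floor lies within the scatter) from compound 3 to compound 4; the limit leaves it open whether they differ

The compounds shown leave open the actual number for compound 4. They also leave open whether a chloro group or an amine in place of bromo, on either of these aromatic carbons, would give steps that match between the two cores.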